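Series notes: cyclic amine variation on the shared core

The compounds below may be only part of what the source reports. "The series", "measured", "known", "first", "only" and "open" are said of these compounds alone.

Measured compounds in a functional assay on CHO-K1 cells for antagonist activity at transient receptor potential cation channel subfamily V member 1 (Homo sapiens), read by FLIPR; a lower number here means a stronger inhibitor, a higher number a weaker inhibitor:
- compound 1 `CC(C(=O)NCc1ccc(C(F)(F)F)nc1NCc1ccccc1)c1ccc(NS(C)(=O)=O)c(F)c1` gives 15.8 nM
- compound 2 `CC(C(=O)NCc1ccc(C(F)(F)F)nc1NCc1ccc(Cl)cc1)c1ccc(NS(C)(=O)=O)c(F)c1` gives 65.7 nM
- compound 3 `CC(C(=O)NCc1ccc(C(F)(F)F)nc1N1CCCCC1C)c1ccc(NS(C)(=O)=O)c(F)c1` gives 2.9 nM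

Compound 3 stands lowest of the three numbers: a 5.4-fold lower number from compound 1 to compound 3 (0.74 log units; beyond the scatter) and a 23-fold lower number from compound 2 to compound 3 (1.36 log units; beyond the scatter), both beyond the scatter. Within the open amines the substitution also matters: a 4.2-fold higher number from compound 1 to compound 2 (0.62 log units; beyond the scatter).

Compound 4 `CC(C(=O)NCc1ccc(C(F)(F)F)nc1N1CCC(c2ccccc2)CC1)c1ccc(NS(C)(=O)=O)c(F)c1` has not been measured. It differs from compound 3 in one place: 4-phenylpiperidin-1-yl in place of 2-methylpiperidin-1-yl on an aromatic carbon. For the measured compounds named here, no measured step alters a substituent within a piperidine ring, so nothing bears on this change directly. The steps that come nearest, a 5.4-fold lower number from compound 1 to compound 3 (0.74 log units; beyond the scatter) and a 23-fold lower number from compound 2 to compound 3 (1.36 log units; beyond the scatter), only show that this position moves the number substantially when the group is exchanged. A modest step in this assay is therefore expected, with a higher number somewhat more likely than a lower one, because a 4.2-fold higher number from compound 1 to compound 2 (0.62 log units; beyond the scatter) went upward when the aromatic portion at this position was enlarged. Compound 4 is expected at 7 nM, with a range of 1.5 nM to 35 nM. The expected step is a 2.4-fold higher number from compound 3 to compound 4 (0.38 log units; beyond the scatter).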

Compound 4, inhibition constant: 0.6 nM
Compound 4: middle estimate off by 12-fold (1.07 log units), on the high side; the measured number lies below the stated range.
By their numbers in this assay, from the lowest: compound 4; then compound 3; then compound 1; then compound 2.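

At this position next to the ring nitrogen, a larger group can go with a lower number: 4-phenylpiperidin-1-yl in place of 2-methylpiperidin-1-yl gives a 4.8-fold lower number from compound 3 to compound 4 (0.68 log units; beyond the scatter) in this assay, so the upward step seen on adding chloro to the benzylamino group does not extend to every added aromatic portion. The same group stands lowest of the four, with a 26-fold lower number from compound 1 to compound 4 (1.42 log units; beyond the scatter) and a 110-fold lower number from compound 2 to compound 4 (2.04 log units; beyond the scatter), and the two piperidine compounds now hold the two lowest numbers, the two benzylamino compounds the two highest. No evidence is at hand on why this step goes downward.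

As far as these compounds go, whether the phenyl itself or its place on the piperidine ring carries the step stays open; 4-methylpiperidin-1-yl and 2-phenylpiperidin-1-yl would separate the two. Also open, from the compounds shown here alone, is how a chloro or a carboxylic acid on that phenyl ring, or a piperazine in place of the piperidine, would move the number.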